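Swapping a benzyl ether for a pyrimidinyl ether

A few compounds are considered here, and "the series" means these few. Any claim that something is new, unique, unknown or untested is made for them only; others in the source may bear on it.

Measured compounds:
- compound 1 `COc1cccc(Oc2c(NS(=O)(=O)c3ccc(C(C)(C)C)cc3)ncnc2OCCOc2ccccc2)c1`: 65 nM
- compound 2 `COc1cccc(Oc2c(NS(=O)(=O)c3ccc(C(C)(C)C)cc3)ncnc2OCCOCc2ccccc2)c1`: 170 nM

Both compounds were tested in an assay on cells (Endothelial cell) for binding affinity to Endothelin-1 receptor (Sus scrofa); on this read-out higher numbers stand for weaker inhibition and lower numbers for stronger inhibition. Compound 2 gives the higher of the two numbers, and its nearest neighbour is compound 1, with a 2.6-fold higher number from compound 1 to compound 2 (0.42 log units; beyond the scatter). That step is the only measured one here, and it is the only one that bears on the change now considered, since it also alters the group on the oxygen on the saturated carbon.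

Compound 3 `COc1cccc(Oc2c(NS(=O)(=O)c3ccc(C(C)(C)C)cc3)ncnc2OCCOc2ncccn2)c1` is not yet measured. It differs from compound 2 by pyrimidin-2-yl in place of benzyl on an oxygen on a saturated carbon. Like compound 1, compound 3 carries an aromatic ring directly on that oxygen, with no extra saturated carbon between. For the measured compounds named here, the one measured step was modest, so a step of similar size, in the direction of a lower number, is expected, a 4.3-fold lower number from compound 2 to compound 3 (0.63 log units; beyond the scatter). For compound 3 the estimate in this assay is 40 nM, with a range from 10 nM to 150 nM.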

Compound 3, half-maximal inhibitory concentration: 1.9 nM
Estimate against measurement, compound 3: 21-fold (1.32 log units) above; the measured number lies below the stated range.
By their numbers in this assay, from the lowest: compound 3; then compound 1; then compound 2.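

In this assay, the earlier pair showed only a modest effect of changing phenyl to benzyl on this oxygen, so the position seemed fairly forgiving. That picture changes with pyrimidin-2-yl on the oxygen: replacing benzyl gives an 89-fold lower number from compound 2 to compound 3 (1.95 log units; beyond the scatter), and replacing phenyl, which also sits directly on the oxygen, gives a 34-fold lower number from compound 1 to compound 3 (1.53 log units; beyond the scatter), so here the kind of ring counts for far more than the extra saturated carbon of benzyl. Nothing available explains why this ring, with its 2 nitrogen atoms, has so large an effect.

Still open, as far as these compounds go, is whether both ring nitrogens are needed, which a pyridin-2-yl group on the same oxygen would test. Also open, from the compounds shown here alone, is how a pyrimidin-2-yl ring carrying an amine, or a longer chain holding the same ring, would read in this assay.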